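Compound 3 to compound 4: a carbamoyl link on the chain

A few compounds are considered here, and "the series" means these few. Any claim that something is new, unique, unknown or untested is made for them only; others in the source may bear on it.

Compound 1 `CCCCCCCCCCCC[C@@H](O)[C@H]1CC[C@H]([C@H](O)CCCCCCCCCCNC(=O)c2ccnn2C)O1`: 10 nM
Compound 2 `CCCCCCCCCCCC[C@@H](O)[C@H]1CC[C@H]([C@H](O)CCCCCCCCCCN(C)C(=O)c2ccnn2C)O1`: 501 nM
Compound 3 `CCCCCCCCCCCC[C@@H](O)[C@H]1CC[C@H]([C@H](O)CCCCCCCCCCNCc2ccnn2C)O1`: 339 nM

All three were tested in a functional assay on BSY-1 cells (Homo sapiens) for inhibition, read by sulforhodamine B assay, with a stated time of 48 h; on this read-out higher numbers stand for weaker inhibition of growth and lower numbers for stronger inhibition of growth. Compound 3 belongs to the upper pair of numbers: it is level with the other member of that pair, a 1.5-fold lower number from compound 2 to compound 3 (0.17 log units; within the scatter), and well apart from the remaining compound, a 34-fold higher number from compound 1 to compound 3 (1.53 log units; beyond the scatter).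

The next molecule is compound 4 `CCCCCCCCCCCC[C@@H](O)[C@H]1CC[C@H]([C@H](O)CCCCCCCCCCC(=O)Nc2ccnn2C)O1`. Its change is (1-methyl-1H-pyrazol-5-yl)carbamoyl in place of ((1-methyl-1H-pyrazol-5-yl)methyl)amino on a saturated chain carbon, ten or more bonds along the chain from an oxygen on a saturated carbon and a saturated ring carbon. In words, (1-methyl-1H-pyrazol-5-yl)carbamoyl stands in place of ((1-methyl-1H-pyrazol-5-yl)methyl)amino on a saturated chain carbon.

Within the data shown here, two measured steps bear on this. Taking away the carbonyl gave a 34-fold higher number from compound 1 to compound 3 (1.53 log units; beyond the scatter), and putting methyl on the amide-type nitrogen gave a 50-fold higher number from compound 1 to compound 2 (1.70 log units; beyond the scatter). Compound 4 has both a carbonyl and an amide hydrogen again, yet its chain carries a carbamoyl group, unlike compound 1. Among the measured compounds shown here, no measured compound tests that difference, so a full return to the 10 nM of compound 1 is not assumed. The expected move in this assay is therefore a partial one toward stronger inhibition, a 5.7-fold lower number from compound 3 to compound 4 (0.75 log units; beyond the scatter). For compound 4 the estimated value is 60 nM, with an expected range of 12 nM to 300 nM.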

Compound 4, concentration for 50% growth inhibition: 95500 nM
Beside the measured number, compound 4's estimate is 1600-fold (3.20 log units) below it; measured number above the stated range.
By their numbers in this assay, from the lowest: compound 1; then compounds 3 and 2 (each within the scatter of the next); then compound 4.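

In this assay the same atoms in the link do not give the same result: (1-methyl-1H-pyrazol-5-yl)carbamoyl in place of ((1-methyl-1H-pyrazol-5-yl)carbonyl)amino gives a 9600-fold higher number from compound 1 to compound 4 (3.98 log units; beyond the scatter) and leaves compound 4 as the weakest of the four. Compound 4 still has a carbonyl and an amide hydrogen, so the earlier losses, seen when the carbonyl was removed or the amide nitrogen was given a methyl, did not show the whole requirement: the order of these parts along the chain counts as well. Against the two weakened compounds the drop is still large, with a 280-fold higher number from compound 3 to compound 4 (2.45 log units; beyond the scatter) and a 190-fold higher number from compound 2 to compound 4 (2.28 log units; beyond the scatter) on top of their own losses, so a changed link at this place can cost far more than a removed carbonyl or an added methyl.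

As far as these compounds go, whether a urea or a sulfonamide link at this place, or a longer chain carrying the same carbamoyl group, would bring back any of the inhibition stays open. Nothing available here gives a reason for the size of this loss.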